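Ethyl Gives Way to 4-Cyanophenyl

The source may hold more compounds than are shown below. What is called first, only, known or untested is meant among the compounds shown, and "the series" means these compounds.

In a physicochemical assay for solubility, at pH 7.4 (a higher number here means a more soluble compound, a lower number a less soluble compound), compound 1 `O=c1cc(-c2ccccc2)nc(-n2cccn2)[nH]1` gives 190000 nM and compound 2 `CCNc1cc(C)nn1-c1nc(C(F)(F)F)cc(=O)[nH]1` gives 85000 nM as the lower of the two numbers. Compound 3 `Cc1cc(Nc2ccc(C#N)cc2)n(-c2nc(C(F)(F)F)cc(=O)[nH]2)n1` differs from compound 2 in one place: 4-cyanophenyl in place of ethyl on a nitrogen on an aromatic ring with 4-cyanophenyl in place of ethyl on a nitrogen on an aromatic ring. Among the measured compounds shown here, no measured pair of compounds shows a change of this kind, so the expectation rests on the structures alone. A clear fall beyond the scatter is expected in this assay with the estimated step of a 7.1-fold lower number from compound 2 to compound 3 (0.85 log units; beyond the scatter) as its size. For compound 3 the estimate is 12000 nM with an expected range from 2500 nM to 45000 nM as its span.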

Compound 3, solubility: 75000 nM
For compound 3 the middle estimate is 6.3-fold (0.80 log units) below the measured one; measured number outside the range, above it.
By their numbers in this assay, from the lowest: compounds 3 and 2 (each within the scatter of the next); then compound 1.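

On a nitrogen on an aromatic ring, swapping ethyl for the much larger 4-cyanophenyl gives a 1.1-fold lower number from compound 2 to compound 3 (0.05 log units; within the scatter) in this assay. This is the first single-place change shown, and it adds an aromatic ring and a nitrile without separating the two numbers beyond the scatter. No measurement available here accounts for this. The compounds shown leave open how a plain phenyl, a longer chain or a carboxylic acid in this place would read in this assay. They also cannot tell whether the ring and the nitrile each matter when taken alone.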